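The source may hold more compounds than are shown below. What is called first, only, known or untested is meant among the compounds shown, and "the series" means these compounds.

Compound 3, `Cc1cn([C@@H]2O[C@H](CO[Si](C)(C)C(C)(C)C)[C@@]3(OS(=O)(=O)C=C3NC(=O)NC(=O)c3ccccc3)[C@H]2O[Si](C)(C)C(C)(C)C)c(=O)n(C)c1=O`, carries a benzoylcarbamoyl group on an amine nitrogen of the shared core. In a functional assay on HEL cells (Homo sapiens) for cytotoxicity, read by microscopy (a lower number here means that less compound is tolerated, a higher number that more compound is tolerated), compound 3 gives only a limit, >= 80000 nM, so its true value is not pinned down as a number. Two other compounds share this core. Compound 1, `Cc1cn([C@@H]2O[C@H](CO[Si](C)(C)C(C)(C)C)[C@@]3(OS(=O)(=O)C=C3NCC(=O)C(=O)N3CCC3)[C@H]2O[Si](C)(C)C(C)(C)C)c(=O)n(C)c1=O`, gives 65000 nM in this assay. Compound 2, `COC(=O)CNC1=CS(=O)(=O)O[C@@]12[C@@H](CO[Si](C)(C)C(C)(C)C)O[C@@H](n1cc(C)c(=O)n(C)c1=O)[C@@H]2O[Si](C)(C)C(C)(C)C`, is also reported only as a limit in this assay, at >= 400000 nM.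

Compound 4, `Cc1cn([C@@H]2O[C@H](CO[Si](C)(C)C(C)(C)C)[C@@]3(OS(=O)(=O)C=C3NCC(=O)C(N)=O)[C@H]2O[Si](C)(C)C(C)(C)C)c(=O)n(C)c1=O`, differs from compound 3 in one place: (carbamoylcarbonyl)methyl in place of benzoylcarbamoyl on an amine nitrogen. The group that enters resembles the side chains of compound 1 and compound 2 more than the group that leaves.

The measured steps give only loose guidance. The step of an at least 1.2-fold higher number from compound 1 to compound 3 (0.09 log units; that floor lies within the scatter) has a floor that sits within the usual scatter, so compound 1 and compound 3 may well be alike. The step that the two limits leave unreadable from compound 2 to compound 3 cannot be read at all, since both ends are limits the limit of >= 400000 nM in this assay, at which 1 of the 3 values shown sits, and (the limit of >= 80000 nM in this assay, at which 1 of the 3 values shown sits). The step of an at least 6.1-fold higher number from compound 1 to compound 2 (0.78 log units; beyond the scatter) shows that exchanging the side chain in this region can shift the number beyond the scatter.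

Given that compound 1 gives 65000 nM and compound 3 gives only >= 80000 nM, compound 4 is expected to land in the same broad region, with a step that the limit leaves unreadable from compound 3 to compound 4 that is not expected to exceed the scatter by much. The estimate for compound 4 in this assay is 100000 nM, between 40000 nM and 400000 nM.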

Compound 4, minimum cytotoxic concentration: >= 16000 nM
Compound 4 was reported as a limit; the forecaster's own chance of this, stated with the estimate: 50%; the middle value lies beyond the limit too.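

In this assay compound 4 is reported only as a limit, >= 16000 nM. No new step can be read from compound 1, compound 2 or compound 3 to compound 4. The compounds shown leave open where the true value of compound 4 lies in this assay, and whether (carbamoylcarbonyl)methyl in place of benzoylcarbamoyl on the amine nitrogen changes the number at all.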